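This account rests on a few compounds, and the source may have more. Where it says the series, first, only, none or still open, it means among the compounds named here.

Measured compounds in a functional assay on Ehrlich cells (Mus musculus) for cytotoxicity, read by trypan blue exclusion, with a stated time of 48 h; on this read-out higher numbers stand for weaker inhibition and lower numbers for stronger inhibition:
compound 1 `Cc1ccc(C(=O)c2ccc(OCC(=O)Nc3nc(-c4ccccc4)cs3)c(C)c2)cc1` gives 28400 nM
compound 2 `COc1ccc(-c2csc(NC(=O)COc3ccc(C(=O)c4ccc(C)cc4)cc3C)n2)cc1` gives 19400 nM
compound 3 `Cc1cc(C(=O)c2ccc(F)cc2)ccc1OCC(=O)Nc1nc(-c2ccccc2)cs1` gives 35200 nM

All three numbers lie within the usual scatter of one another, so none of the three can be set apart from the others in this assay. The change from compound 1 to compound 2 is methoxy in place of hydrogen on an aromatic carbon and it made a step of a 1.5-fold lower number from compound 1 to compound 2 (0.17 log units; within the scatter). The change from compound 1 to compound 3, which is the difference between the cores of compound 1 and compound 3, is fluoro in place of methyl on an aromatic carbon and it made a step of a 1.2-fold higher number from compound 1 to compound 3 (0.09 log units; within the scatter).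

Compound 4 `COc1ccc(-c2csc(NC(=O)COc3ccc(C(=O)c4ccc(F)cc4)cc3C)n2)cc1` has not yet been measured in this assay. It differs from compound 3 by methoxy in place of hydrogen on an aromatic carbon, and the place of this change is described in the same words as for the change from compound 1 to compound 2, so it is the same change carried onto the core of compound 3. Within the data shown here, since that change made only a small step from compound 1 to compound 2, the step from compound 3 to compound 4 is expected to be of a similar size, a 1.5-fold lower number from compound 3 to compound 4 (0.18 log units; within the scatter), and this expectation rests on the single pair, compound 1 to compound 2, with a 1.5-fold lower number from compound 1 to compound 2 (0.17 log units; within the scatter). Compound 4 is therefore estimated to give 23500 nM in this assay, with a plausible range from 12000 nM to 45000 nM.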

Compound 4, half-maximal inhibitory concentration: 5200 nM
Compound 4: middle estimate off by 4.5-fold (0.66 log units), on the high side, and the stated range ends above it.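

In this assay, methoxy in place of hydrogen on an aromatic carbon made a 6.8-fold lower number from compound 3 to compound 4 (0.83 log units; beyond the scatter), so the small step seen on the core of compound 1 did not carry over in size onto the core of compound 3: the same change on two cores in this assay, a 1.5-fold lower number (0.17 log units; within the scatter) from compound 1 to compound 2 and a 6.8-fold lower number (0.83 log units; beyond the scatter) from compound 3 to compound 4, 4.6-fold (0.67 log units) apart, beyond the scatter of two such steps. Read the other way, fluoro in place of methyl on an aromatic carbon made a 3.7-fold lower number from compound 2 to compound 4 (0.57 log units; beyond the scatter), and this step too differs from its earlier counterpart: the same change on two cores in this assay, a 1.2-fold higher number (0.09 log units; within the scatter) from compound 1 to compound 3 and a 3.7-fold lower number (0.57 log units; beyond the scatter) from compound 2 to compound 4, 4.6-fold (0.67 log units) apart, beyond the scatter of two such steps. Both gaps rest on the same four values and so form a single observation: in this set the methoxy and fluoro changes do not act independently of each other, but the values do not show why, or whether the same would hold on any other core.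

The compounds shown leave open whether another group in the place of the methoxy, such as a hydroxyl, an amine or a longer alkoxy chain, would also differ in its step between the two cores. They also leave open whether chloro or trifluoromethyl in the place of the fluoro would go together with methoxy as fluoro does in compound 4.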